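A few compounds are considered here, and "the series" means these few. Any claim that something is new, unique, unknown or untested is made for them only; others in the source may bear on it.

Measured so far:
compound 1, `COc1ccc(CS(=O)(=O)/C=C/c2ccc(OC)c(OC)c2OC)cc1[N+](=O)[O-]`: 21900 nM
compound 2, `COc1ccc(CS(=O)(=O)CC(=O)Nc2c(C)cc(C)cc2C)cc1[N+](=O)[O-]`: > 30000 nM
compound 3, `COc1ccc(CS(=O)(=O)/C=C/c2ccc(OC)c(OC)c2OC)cc1N`: 3480 nM

All three were tested in a functional assay on MDA-MB-468 cells (Homo sapiens) for cytotoxicity, read by MTT assay, with a stated time of 72 h; on this read-out higher numbers stand for weaker inhibition of growth and lower numbers for stronger inhibition of growth. In this assay compound 1 gives 21900 nM. Compound 3 differs from compound 1 in one place, (amino in place of nitro on an aromatic carbon), and in this assay compound 3 gives 3480 nM. That single change made the step of a 6.3-fold lower number from compound 1 to compound 3 (0.80 log units; beyond the scatter), so the growth inhibition became clearly stronger.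

Compound 2 stands at the limit of > 30000 nM in this assay, at which 1 of the 3 values shown sits. For compound 2 this assay therefore gives no number, only a limit. Compound 1 and compound 2 share the same end of the molecule on which the nitro group sits, but the difference between the two cores is not broken down here.

Compound 4, `COc1ccc(CS(=O)(=O)CC(=O)Nc2c(C)cc(C)cc2C)cc1N`, has not yet been measured. Among the measured compounds shown here, it differs from compound 2 by amino in place of nitro on an aromatic carbon, which is the same change as the one that turned compound 1 into compound 3, at a place described in the same words. In this assay the expected step is an at least 2.5-fold lower number from compound 2 to compound 4 (0.39 log units; beyond the scatter), which rests on a 6.3-fold lower number from compound 1 to compound 3 (0.80 log units; beyond the scatter) and on compound 2 being known only as a limit, so its true starting point may lie well beyond that limit and the outcome is uncertain. Compound 4 is estimated at 12000 nM, with a likely range from 3000 nM to 40000 nM, and a real chance that this assay again reports only a limit.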

Compound 4, concentration for 50% growth inhibition: > 30000 nM
Compound 4 ended at the assay's limit; the forecaster's own chance of this, stated with the estimate: 35%; middle value at least 2.5-fold (0.39 log units) away from the limit.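

In this assay, compound 2 and compound 4 both end at the same limit and not at a number, so no step between them can be read: the limit of > 30000 nM in this assay, at which 2 of the 4 values shown sit.

The compounds shown leave open whether amino in place of nitro changes growth inhibition at all on the core of compound 2, as it did on the core shared by compound 1 and compound 3.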